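A few compounds are considered here, and "the series" means these few. Any claim that something is new, unique, unknown or untested is made for them only; others in the source may bear on it.

Measured so far:
compound 1 `Brc1cn2ccnc2c(-c2ccc3ncn(C4CCCCC4)c3c2)n1` — 26.8%
compound 2 `c1cn2cc(-c3ccsc3)nc(-c3ccc4ncn(C5CCCCC5)c4c3)c2n1` — 14.3%

In a functional assay on SR cells (Homo sapiens) for inhibition, read by sulforhodamine B assay, with a stated time of 48 h, tested at 10 uM (a higher number here means more inhibition at the concentration tested (going by the name of the read-out), a lower number less inhibition), compound 2 gives 14.3%, the lower of the two numbers; the nearest is compound 1 with 26.8%, a gap beyond the scatter. Compound 3 `Clc1ccc(-c2cn3ccnc3c(-c3ccc4ncn(C5CCCCC5)c4c3)n2)cc1` is the next point in the series, and it differs from compound 2 as follows: 4-chlorophenyl in place of thiophen-3-yl on an aromatic carbon. For the measured compounds named here, the only measured step at this position is a number 12.5 percentage points lower from compound 1 to compound 2 (beyond the scatter), which put an aromatic ring in place of bromo and lowered the read-out by a modest amount. Going by the values given here, no measured pair exchanges one aromatic ring for another at this carbon, so that step bears only indirectly; the two aryl compounds here are likely to sit close together. For compound 3 the expected change is therefore a number 4.7 percentage points higher from compound 2 to compound 3 (within the scatter), within the scatter. Compound 3 is estimated at 19%, with a range from 5% to 36%.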

Compound 3, a percentage reported as inhibition, at one concentration (the size of the read-out at that concentration, not a potency): 18.5%
The estimate for compound 3 lay 0.5 percentage points above the measured number; low and high end bracket the measured number.
By their numbers in this assay, from the lowest: compounds 2, 3 and 1 (each within the scatter of the next, the first and the last beyond it).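

In this assay, for the compounds shown here, the first aromatic-for-aromatic exchange at this carbon gives a number 4.2 percentage points higher from compound 2 to compound 3 (within the scatter) and so does not separate thiophen-3-yl, a five-membered aromatic ring with a hetero atom, from 4-chlorophenyl, a six-membered aromatic ring of carbon only. Replacing bromo with 4-chlorophenyl gives a number 8.3 percentage points lower from compound 1 to compound 3 (within the scatter) and so does not repeat, beyond the scatter, the step seen with thiophen-3-yl. A general loss on replacing bromo with an aromatic ring therefore cannot be claimed from these compounds, with compound 2 alone lying beyond the scatter of compound 1. No measurement on hand accounts for these numbers.

Still open, on these data alone, is whether an amine or a carboxylic acid at this carbon would move the read-out beyond the scatter of these three compounds. A phenyl ring carrying a methoxy group in place of chlorine also remains to be placed.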